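The compounds below may be only part of what the source reports. "The series", "measured", "known", "first", "only" and "open" are said of these compounds alone.

Measured so far:
compound 1 `C=C(C)C(=O)c1ccc(OC)cc1OC` — 31.5%
compound 2 `CCOC(=O)c1nn(-c2ccccc2)c(-c2ccc(OC)cc2OC)c1-c1ccccc1` — 20.8%
compound 3 `CCOC(=O)C(=O)C(C(=O)c1ccc(OC)cc1OC)c1ccccc1` — 20.8%

All three numbers come from a functional assay on the whole organism (strain albino) for inhibition, with Rattus norvegicus as the target, read by paw edema, with stated times of 30 min and 3 h, at a dose of 25 mg/kg by the intraperitoneal route; a lower number here means less inhibition, a higher number more inhibition at the dose given (going by the name of the read-out). Compound 3 stands level with compound 2 at the digits printed, and together the two form the lowest pair of the three; the gap between compound 3 and compound 2 lies within the scatter. Compound 1 stands higher than compound 3 by a margin beyond the scatter. Within the data shown here, no two of the measured compounds differ in a single place, so no step between measured compounds is available to lean on.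

Compound 4 `CCOC(=O)C(=O)C(C)C(=O)c1ccc(OC)cc1OC` is the next member, not yet measured in this assay. It differs from compound 3 by methyl in place of phenyl on a saturated chain carbon bound to two carbonyl carbons. Among the measured compounds shown here, nothing among the measured compounds shows how this change plays out, so no step beyond the scatter is expected in either direction; the estimate for the step from compound 3 to compound 4 is a number 1.2 percentage points higher from compound 3 to compound 4 (within the scatter). Compound 4 is therefore expected to read near compound 3, at an estimated 22%, with a range from 10% to 35%.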

Compound 4, a percentage reported as inhibition, in the whole organism at one dose (the size of the read-out at that dose, not a potency): 26.1%
Estimate against measurement, compound 4: 4.1 percentage points below; low and high end bracket the measured number.
By their numbers in this assay, from the lowest: compounds 2, 3, 4 and 1 (each within the scatter of the next, the first and the last beyond it).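

In this assay, methyl in place of phenyl on a saturated chain carbon bound to two carbonyl carbons gives a number 5.3 percentage points higher from compound 3 to compound 4 (within the scatter), the first single-place step available in this series. At this position, the read-out at the dose given therefore does not separate the two groups, even though a six-membered aromatic ring of six carbons leaves and a single carbon enters. No measurement shown bears on why the two groups read alike.

Still open, going by these compounds, is whether any group at this position moves the read-out beyond the scatter, such as a hydrogen, a longer chain, an amine or a carboxylic acid. As each number is the size of the effect at one dose, the step also leaves open whether potency differs between the two compounds.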